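Shifting a methoxy group from compound 2 to compound 4

The source may report more compounds than this note shows. Statements on the series, on what has been measured and on what is new or still open speak of the compounds shown alone.

- compound 1 `COc1ccc(/C=C/C(=O)c2cccc(-c3ccc(F)cc3)c2)cc1` gives 16400 nM
- compound 2 `COc1ccc(-c2cc(C(=O)/C=C/c3cccc(OC)c3OC)ccc2N)cc1OC` gives 10200 nM
- compound 3 `COc1ccc(/C=C/C(=O)c2ccc(N)c(-c3ccc(F)cc3)c2)cc1OC` gives 15000 nM

All three values come from a functional assay on MCF7 cells (Homo sapiens) for cytotoxicity, read by sulforhodamine B assay, with a stated time of 48 h (a higher number here means a weaker inhibitor, a lower number a stronger inhibitor), and cannot be told apart. Compound 2, at 10200 nM, lies within the usual scatter of both other compounds, so it stands with them and not ahead of them.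

The next compound to be read is compound 4 `COc1ccc(/C=C/C(=O)c2ccc(N)c(-c3ccc(OC)c(OC)c3)c2)c(OC)c1`. It differs from compound 2 in one place: 2,4-dimethoxyphenyl in place of 2,3-dimethoxyphenyl on a double-bonded chain carbon bound to a double-bonded chain carbon. This puts 2,4-dimethoxyphenyl in place of 2,3-dimethoxyphenyl on a double-bonded chain carbon bound to a double-bonded chain carbon.

For the measured compounds named here, no two measured compounds differ in one place only, so the size of such a change has not been observed directly. The expectation therefore rests on the overall spread, with compound 3 at 15000 nM and compound 1 at 16400 nM both within the scatter of compound 2. No step beyond the scatter is expected in either direction. The estimate is a 1.2-fold higher number from compound 2 to compound 4 (0.07 log units; within the scatter) and this small shift towards a higher number is expected. For compound 4 the estimated value is 12000 nM with an expected range from 6000 nM to 24000 nM in this assay once it is measured.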

Compound 4, half-maximal inhibitory concentration: 6490 nM
Compound 4: middle estimate off by 1.8-fold (0.27 log units), on the high side; measured number inside the range.
By their numbers in this assay, from the lowest: compounds 4, 2, 3 and 1 (each within the scatter of the next, the first and the last beyond it).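

In this assay, 2,4-dimethoxyphenyl in place of 2,3-dimethoxyphenyl on a double-bonded chain carbon bound to a double-bonded chain carbon gives a 1.6-fold lower number from compound 2 to compound 4 (0.20 log units; within the scatter), and this is the only direct reading of a single change among the compounds shown. The two groups have the same atoms and the same counts of donors and acceptors, so the step isolates how the two methoxy groups are arranged on that ring, and at this place the two arrangements cannot be told apart in this read-out. Nothing measured here offers a reason for the size of this step or tells what the methoxy groups contribute.

Still open, going by these compounds, is whether the same place tolerates a larger change, such as a hydroxyl group in place of each methoxy group or a pyridine ring in place of the dimethoxyphenyl ring, since both dimethoxyphenyl groups carry the same atoms and say nothing about a different group there. The contribution of the amine on the core also remains open, as no two compounds shown differ in that group alone.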